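A few compounds are considered here, and "the series" means these few. Any claim that something is new, unique, unknown or untested is made for them only; others in the source may bear on it.

Compound 1 `CCOC(=O)c1cnc(-c2ccccc2F)[nH]c1=O`: > 10 mg/kg
Compound 2 `CCOC(=O)c1cnc(-c2ccccc2[N+](=O)[O-])[nH]c1=O`: "not determined" (no result reported)
Compound 3 `CCOC(=O)c1cnc(-c2ccccc2OC(C)C)[nH]c1=O`: 2 mg/kg

For the measured compounds named here, in a functional assay on the whole organism (strain Sprague-Dawley) for inhibition, with Rattus norvegicus as the target, with a stated time of 10 min (on this read-out lower numbers stand for an effect already at smaller amounts and higher numbers for an effect only at larger amounts of compound), compound 3 gives 2 mg/kg, the only true number in this small set. Compound 1 gives > 10 mg/kg, which is a limit of the assay and not a number. Compound 2 carries the entry "not determined" (no result reported), so it offers no comparison.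

The next compound to be tested is compound 4 `CCCCOc1ccccc1-c1ncc(C(=O)OCC)c(=O)[nH]1`. It keeps everything in compound 3 except one group: butyl in place of isopropyl on an oxygen on an aromatic ring.

Going by the values given here, only one measured step bears on this, and only indirectly. Putting isopropoxy in place of fluoro gave an at least 5.0-fold lower number from compound 1 to compound 3 (0.69 log units; beyond the scatter), a change beyond the scatter that rests on the limit (the limit of > 10 mg/kg in this assay, at which 1 of the 3 values shown sits). That step suggests that an alkoxy group can go with a useful effect, but it compares no two alkyl chains. The swap to butoxy keeps the oxygen and changes only the chain, so no clear move in either direction is expected in this assay. The estimated change is a 1.3-fold higher number from compound 3 to compound 4 (0.10 log units; within the scatter), which is no step beyond the scatter. For compound 4 the expected value is 2.5 mg/kg, with an estimated range from 0.7 mg/kg to 10 mg/kg.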

Compound 4, dose for 50% inhibition: 0.5 mg/kg
Compound 4: the middle estimate sits 5.0-fold (0.70 log units) above what was measured; the measured number lies below the stated range.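

In this assay, the alkyl chain on the oxygen turns out to matter in its own right: butyl in place of isopropyl gave a 4.0-fold lower number from compound 3 to compound 4 (0.60 log units; beyond the scatter), with the oxygen and the rest of the molecule unchanged. The earlier compounds shown here compared an alkoxy group only with fluoro, so they could not show that two alkoxy groups differ at this place, whereas butoxy in place of fluoro now gives an at least 20-fold lower number from compound 1 to compound 4 (1.30 log units; beyond the scatter). Compound 1 carries a limit of the assay and not a number, and this second step rests on that limit: the limit of > 10 mg/kg in this assay, at which 1 of the 4 values shown sits.

Isopropyl is branched and butyl is a straight chain with one more carbon, so the compounds shown cannot tell whether the branching or the extra carbon accounts for the step. From the compounds shown here alone, whether a longer chain such as hexyl lowers the number further, or whether a branched butyl such as isobutyl or an amine at the end of the chain keeps the effect, also stays open.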